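The source may hold more compounds than are shown below. What is called first, only, known or untested is meant among the compounds shown, and "the series" means these compounds.

In an ADME assay on HepG2 cells (Homo sapiens) for cytotoxicity, read by resazurin assay, with a stated time of 48 h (on this read-out higher numbers stand for an effect only at larger amounts of compound and lower numbers for an effect already at smaller amounts), three compounds built on one shared core have been measured so far. Compound 3 `O=C(Nc1ccc(F)c(-c2nc3ncc(-c4ccc(F)cc4)cc3[nH]2)c1)N1CCCC1` gives > 50000 nM, which is a limit of the assay and not a number. Compound 1 `O=C(Nc1ccc(F)c(-c2nc3ncc(-c4ccc(F)c(F)c4)cc3[nH]2)c1)N1CCCC1` gives > 50000 nM, also a limit. Among the compounds with values here, compound 2 `O=C(Nc1ccc(F)c(-c2nc3ncc(-c4ccc(F)cc4F)cc3[nH]2)c1)N1CCCC1` gives 32400 nM, the only true number of the three. Compound 3 therefore stands at the limit of > 50000 nM in this assay, at which 2 of the 3 values shown sit.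

Compound 4 `O=C(Nc1ccc(F)c(-c2nc3ncc(-c4ccc(F)nc4)cc3[nH]2)c1)N1CCCC1` has not yet been measured. It differs from compound 3 in one place: 6-fluoropyridin-3-yl in place of 4-fluorophenyl on an aromatic carbon. In words, 6-fluoropyridin-3-yl stands in place of 4-fluorophenyl on an aromatic carbon. The measured steps that bear on this change all alter the fluoro substitution of the group at that same place: an at least 1.5-fold lower number from compound 1 to compound 2 (0.18 log units; that floor lies within the scatter), an at least 1.5-fold higher number from compound 2 to compound 3 (0.18 log units; that floor lies within the scatter) and a step that the two limits leave unreadable from compound 1 to compound 3. Two of these give only a floor and the third cannot be read. None of them puts a ring nitrogen into that group, so the data hold no direct measure of this change.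

No step beyond the scatter is therefore expected in this assay, and no direction can be told with confidence. The expectation leans on compound 2 at 32400 nM, the nearest true number. The estimated change is an at least 1.1-fold lower number from compound 3 to compound 4 (0.04 log units; that floor lies within the scatter). For compound 4 the expected value is 45000 nM, with an estimated range from 22000 nM to 90000 nM.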

Compound 4, half-maximal effective concentration: > 50000 nM
Compound 4 gave a limit, no number; the forecaster's own chance of this, stated with the estimate: 60%; at least 1.1-fold (0.04 log units) between middle value and limit.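

The earlier compounds shown here carried only fluorinated phenyl groups at this position, and compound 4 shows that a ring nitrogen can stand in that group without bringing a true number into this assay. Within the data shown here, compound 4 gives only a limit of the assay and not a number, and it joins compound 1 and compound 3 there: the limit of > 50000 nM in this assay, at which 3 of the 4 values shown sit. The one step that can be read is an at least 1.5-fold higher number from compound 2 to compound 4 (0.18 log units; that floor lies within the scatter), so the swap of 2,4-difluorophenyl for 6-fluoropyridin-3-yl shows no step beyond the scatter, while the steps from compound 1 and from compound 3 to compound 4 cannot be read, both ends being limits.

Going by these compounds, whether the ring nitrogen changes the read-out at all stays open, since compound 1, compound 3 and compound 4 cannot be told apart and compound 2 alone carries a true number. Also open, on these data alone, is whether an amine or a carboxylic acid on that ring, in place of the fluoro of 6-fluoropyridin-3-yl, would give a true number or stay at the limit.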